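Tert-butyl step carried from one benzyloxy core to a methoxy core

A few compounds are considered here, and "the series" means these few. Any claim that something is new, unique, unknown or untested is made for them only; others in the source may bear on it.

Measured compounds, in a functional assay on U-937 cells (Homo sapiens) for antiproliferative activity, read by MTT assay, with a stated time of 24 h; on this read-out higher numbers stand for weaker inhibition and lower numbers for stronger inhibition:
- compound 1 `O=C1NC(O)(CCn2cc(-c3ccccc3)nn2)C(OCc2ccccc2)=C1OCc1ccccc1` gives 21500 nM
- compound 2 `CC(C)(C)c1ccc(-c2cn(CCC3(O)NC(=O)C(OCc4ccccc4)=C3OCc3ccccc3)nn2)cc1` gives 56500 nM
- compound 3 `COC1=C(OC)C(O)(CCn2cc(-c3ccccc3)nn2)NC1=O` gives 20300 nM

Compound 1 and compound 2 share a core and differ by tert-butyl in place of hydrogen on an aromatic carbon. That change gave a 2.6-fold higher number from compound 1 to compound 2 (0.42 log units; beyond the scatter) in this assay, a modest weakening.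

Compound 3 carries a different core; how the cores of compound 1 and compound 3 differ is not broken down here. Its value in this assay lies within the scatter of compound 1, so the two are not ordered against each other, while compound 2 stands higher than both.

Compound 4 `COC1=C(OC)C(O)(CCn2cc(-c3ccc(C(C)(C)C)cc3)nn2)NC1=O` is not yet measured. It differs from compound 3 by tert-butyl in place of hydrogen on an aromatic carbon, the same change as from compound 1 to compound 2, at the same place. On that single precedent, the step is expected to be of similar size, a 2.5-fold higher number from compound 3 to compound 4 (0.39 log units; beyond the scatter) in this assay, because a 2.6-fold higher number from compound 1 to compound 2 (0.42 log units; beyond the scatter) was seen on the other core. The estimate for compound 4 in this assay is 50000 nM, expected between 24000 nM and 110000 nM, with some chance that only a limit is reported.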

Compound 4, half-maximal inhibitory concentration: > 100000 nM
Compound 4 gave a limit, no number (the forecaster's own chance of this, stated with the estimate: 15%); middle value at least 2.0-fold (0.30 log units) from the limit.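

In this assay, tert-butyl in place of hydrogen on an aromatic carbon moves the number in the same direction on both cores, and on the core of compound 3 the change gives an at least 4.9-fold higher number from compound 3 to compound 4 (0.69 log units; beyond the scatter). Compound 4 gives > 100000 nM, which is a limit of the assay and not a number: the limit of > 100000 nM in this assay, at which 1 of the 4 values shown sits. The direction of the change thus holds on the two cores shown, but whether its size depends on the core cannot be read: the same change on two cores in this assay, a 2.6-fold higher number (0.42 log units; beyond the scatter) from compound 1 to compound 2 and an at least 4.9-fold higher number (0.69 log units; beyond the scatter) from compound 3 to compound 4; the limit leaves it open whether they differ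

The compounds shown leave open how a methyl, an amine or a carboxylic acid in place of that hydrogen would read in this assay, on either core. They also leave open whether any replacement at that place gives a lower number than the unsubstituted phenyl compounds, since tert-butyl is the only group shown there.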